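A few compounds are considered here, and "the series" means these few. Any claim that something is new, unique, unknown or untested is made for them only; others in the source may bear on it.

In a functional assay on the whole organism with Mus musculus as the target, in the maximal electroshock model (on this read-out lower numbers stand for an effect already at smaller amounts and higher numbers for an effect only at larger amounts of compound), compound 1 `CNC(=O)[C@@H](C)NCc1ccc(OCc2ccccc2)cc1` gives 7 mg/kg and compound 2 `C[C@@H](NCc1ccc(SCc2ccccc2)cc1)C(N)=O` gives 8.6 mg/kg while compound 3 `CNC(=O)[C@@H](CO)NCc1ccc(OCc2cccc(C)c2)cc1` stands highest of the three at 30.6 mg/kg with its gaps to both others beyond the scatter. Compound 4 `CNC(=O)[C@@H](CO)NCc1ccc(OCc2cccc(F)c2)cc1` differs from compound 3 in one place, with fluoro in place of methyl on an aromatic carbon meta to a large group. Going by the values given here, no measured pair in this set isolates that change, so the expectation has no direct support. A slightly lower number is expected, with an estimated 1.5-fold lower number from compound 3 to compound 4 (0.18 log units; within the scatter) in this assay and thus no step beyond the scatter. For compound 4 the estimate is 20 mg/kg with an expected range from 9 mg/kg to 42 mg/kg for a single measurement.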

Compound 4, dose for half-maximal effect: 13 mg/kg
Compound 4: middle estimate off by 1.5-fold (0.19 log units), on the high side; low and high end bracket the measured number.
By their numbers in this assay, from the lowest: compounds 1, 2 and 4 (each within the scatter of the next); then compound 3.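

Going by these compounds alone, exchanging 3-methylphenyl for 3-fluorophenyl gives a 2.4-fold lower number from compound 3 to compound 4 (0.37 log units; beyond the scatter), the first comparison that differs in one place. The read-out therefore responds to the group on this aromatic carbon, even though the exchange swaps one heavy atom for another and leaves the hydrogen-bond donor and acceptor counts unchanged. Nothing measured here accounts for the step.

From the compounds shown here alone, whether chloro, methoxy or trifluoromethyl at the same place, or no substituent at all, would lower the number further remains open. Also open, going by these compounds, is whether fluoro in place of methyl gives a similar step on the cores of compound 1 and compound 2.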